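A few compounds are considered here, and "the series" means these few. Any claim that something is new, unique, unknown or untested is made for them only; others in the source may bear on it.

In a physicochemical assay for solubility, read by HPLC, with a stated time of 24 h (on this read-out higher numbers stand for higher solubility and lower numbers for lower solubility), compound 1 `CC(C)(C)c1[nH]cnc1/C=c1\[nH]c(=O)/c(=C/c2cccc(C(=O)c3cccs3)c2)[nH]c1=O` gives < 0.1 ug/mL, which is a limit of the assay. Compound 2 `CC(C)(C)c1[nH]cnc1/C=c1\[nH]c(=O)/c(=C/c2cccc(C(=O)c3cncs3)c2)[nH]c1=O` gives < 0.1 ug/mL, which is likewise a limit and not a number. Among the compounds with values here, the only measured step is a step that the two limits leave unreadable from compound 1 to compound 2, and the evidence on it is the limit of < 0.1 ug/mL in this assay, at which 2 of the 2 values shown sit. Compound 3 `CC(C)(C)c1[nH]cnc1/C=c1\[nH]c(=O)/c(=C/c2cccc(C(=O)c3ccoc3)c2)[nH]c1=O` differs from compound 2 as follows: furan-3-yl in place of 1,3-thiazol-5-yl on a carbonyl carbon. That measured step offers no size to carry over, so no change beyond the scatter is expected in this assay, and no direction can be given. The expected step is a step that the limit leaves unreadable from compound 2 to compound 3. Compound 3 is estimated at 0.08 ug/mL, with an expected range of 0.03 ug/mL to 0.3 ug/mL.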

Compound 3, solubility: < 0.1 ug/mL
Compound 3: a limit, no number (the forecaster's own chance of this, stated with the estimate: 85%); the middle value does not contradict the limit.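

Compound 1, compound 2 and compound 3 all sit at a limit in this assay, so no step among them can be read: the limit of < 0.1 ug/mL in this assay, at which 3 of the 3 values shown sit.

What the compounds shown leave open is how far their solubility lies from that limit, and whether the group on the carbonyl carbon changes it at all.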